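Removing One Methyl Group: Expected Effect on Cytotoxicity

A few compounds are considered here, and "the series" means these few. Any claim that something is new, unique, unknown or untested is made for them only; others in the source may bear on it.

Measured so far in a functional assay on L6 cells (Rattus norvegicus) for cytotoxicity; a lower number here means a stronger inhibitor, a higher number a weaker inhibitor:
Compound 1 `CN(C)c1nc(N/N=C/c2ccc([N+](=O)[O-])o2)nc(N(C)C)n1` gives 18700 nM.
Compound 2 `CN(C)c1nc(N)nc(N/N=C/c2ccc([N+](=O)[O-])o2)n1` gives 110000 nM.
Compound 3 `Nc1nc(N)nc(N/N=C/c2ccco2)n1` reaches only a limit of the assay, > 400000 nM.

Compound 2 has the highest of the two numbers shown. For the measured compounds named here, the one measured step that reaches it, a 5.9-fold higher number from compound 1 to compound 2 (0.77 log units; beyond the scatter), shows that swapping dimethylamino for amino weakens inhibition. Going by the values given here, compound 4 `CNc1nc(N)nc(N/N=C/c2ccc([N+](=O)[O-])o2)n1` differs from compound 2 by hydrogen in place of methyl on a nitrogen on an aromatic ring, so the change is dimethylamino to methylamino, a smaller change than the one seen between compound 1 and compound 2. Compound 3, carrying amino groups throughout, sits at the limit of > 400000 nM in this assay, at which 1 of the 3 values shown sits. A modest weakening, smaller than the measured step, is therefore expected. Compound 4 is estimated at 200000 nM, within 80000 nM to 500000 nM. This expected step is a 1.8-fold higher number from compound 2 to compound 4 (0.26 log units; within the scatter).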

Compound 4, half-maximal inhibitory concentration: 48900 nM
Beside the measured number, compound 4's estimate is 4.1-fold (0.61 log units) above it; measured number outside the range, below it.
By their numbers in this assay, from the lowest: compound 1; then compound 4; then compound 2. At a limit, above all of these: compound 3.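

Taking one methyl off the dimethylamino group of compound 2 leaves methylamino and gives a 2.2-fold lower number from compound 2 to compound 4 (0.35 log units; beyond the scatter) in this assay and so runs the opposite way to a 5.9-fold higher number from compound 1 to compound 2 (0.77 log units; beyond the scatter) where a dimethylamino group became amino. Among these compounds, then, losing methyl from such a nitrogen does not move the number in one fixed direction. Nothing measured here accounts for this difference.

Still open, from the compounds shown here alone, is how an ethylamino group or a plain amino group would read on this nitrogen of the same core. Going by these compounds, a cyclic amine such as morpholine in that place remains equally open.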